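Side-chain variation on the shared core

The source may report more compounds than this note shows. Statements on the series, on what has been measured and on what is new or still open speak of the compounds shown alone.

Compound 1 `COc1cc(OC)c2c(=O)cc(-c3ccc(OCCF)cc3)oc2c1` is reported in a functional assay (Homo sapiens) for antiproliferative activity, read by resazurin assay, with a stated time of 48 h, tested at 10 uM (on this read-out higher numbers stand for a stronger effect at the one concentration tested and lower numbers for a weaker effect), as "not active" (no number reported); no number is attached, so compound 1 cannot be placed on the scale beyond that. Compound 2 `COc1cc(OC)c2c(=O)cc(-c3ccc(OCCCN(C)C)cc3)oc2c1` in this assay gives 59%. Compound 3 `COc1cc(OC)c2c(=O)cc(-c3ccc(OCC(O)CO)cc3)oc2c1` is not yet tested. The change from compound 1 to compound 3 is 1,2-dihydroxyethyl in place of fluoromethyl on a saturated chain carbon bound to an oxygen on an aromatic ring. Among the compounds with values here, no measured step covers this change; in this assay a small rise is expected, not clearly beyond the scatter. Compound 3 is therefore estimated at 15%, within a range of 0% to 40%.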

Compound 3, a percentage reported as inhibition, at one concentration (the size of the read-out at that concentration, not a potency): 11%
The estimate for compound 3 lay 4 percentage points above the measured number; the measured number falls inside the stated range.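

In this assay, within the data shown here, the one readable step at this position, 1,2-dihydroxyethyl in place of 2-(dimethylamino)ethyl, is a number 48 percentage points lower from compound 2 to compound 3 (beyond the scatter), so on the shared core the outcome depends strongly on which side chain is present. Compound 1 is reported as "not active" (no number reported), so its difference from compound 3 cannot be read as a step. Nothing given here explains the size of the step.

Open, on these data alone, is whether the dimethylamino group or the chain carrying it sets the result. A morpholine, a primary amine or a carboxylic acid on the same chain would help separate the two.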